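The source may report more compounds than this note shows. Statements on the series, on what has been measured and on what is new or still open speak of the compounds shown alone.

Measured in a functional assay on B16 cells (Mus musculus) for cytotoxicity, read by MTT assay, with a stated time of 48 h; on this read-out lower numbers stand for stronger inhibition and higher numbers for weaker inhibition:
Compound 1 `C#CCNC(=O)c1cn(Cc2ccccc2)nn1`: 65000 nM
Compound 2 `C#Cc1cccc(NC(=O)c2cn(Cc3ccccc3)nn2)c1`: 14500 nM
Compound 3 `C#Cc1ccc(NC(=O)c2cn(Cc3ccccc3)nn2)cc1`: > 100000 nM

Compound 3 reads > 100000 nM in this assay, and that is a limit of the assay, not a number. Compound 4 `O=C(Nc1ccccc1)c1cn(Cc2ccccc2)nn1` comes from compound 3 by one change: hydrogen in place of ethynyl on an aromatic carbon. Going by the values given here, no measured pair of compounds shows this change on its own. Compound 2 also carries ethynyl and gives 14500 nM, so carrying that group does not by itself rule out a measurable value. A modest move toward stronger inhibition is expected in this assay, though the result may stay at the limit. The expected change is an at least 1.6-fold lower number from compound 3 to compound 4 (0.22 log units; that floor lies within the scatter). For compound 4 the estimate is 60000 nM, with an expected range of 18000 nM to 100000 nM.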

Compound 4, half-maximal inhibitory concentration: 93000 nM
For compound 4 the middle estimate is 1.6-fold (0.19 log units) below the measured one; low and high end bracket the measured number.
By their numbers in this assay, from the lowest: compound 2; then compounds 1 and 4 (each within the scatter of the next). At a limit, above all of these: compound 3.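

In this assay, hydrogen in place of ethynyl weakens inhibition clearly at the ring place that compound 2 uses (a 6.4-fold higher number from compound 2 to compound 4 (0.81 log units; beyond the scatter)). Phenyl in place of propargyl on the amide-type nitrogen leaves no difference beyond the scatter (a 1.4-fold higher number from compound 1 to compound 4 (0.16 log units; within the scatter)). Para to a large group, the same ethynyl change gives only a floor (an at least 1.0-fold lower number from compound 3 to compound 4 (0.03 log units; that floor lies within the scatter)), because compound 3 stands at a limit, not a number: the limit of > 100000 nM in this assay, at which 1 of the 4 values shown sits.

Going by these compounds, whether an amine or a carboxylic acid para to a large group would give a clearly stronger number stays open. So does the effect of a longer chain in place of propargyl.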